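This account rests on a few compounds, and the source may have more. Where it says the series, first, only, none or still open, it means among the compounds named here.

Measured in a functional assay on MCF7 cells (Homo sapiens) for antiproliferative activity, read by MTT assay, with a stated time of 72 h; on this read-out lower numbers stand for stronger inhibition and higher numbers for weaker inhibition:
- compound 1 `CC1=CC[C@H]2[C@H](CC[C@]2(C)O)C(C)(C)[C@@H]1CC[C@H]1[C@]2(C)CC[C@H](OC(=O)c3ccc(F)cc3)C(C)(C)O[C@H]2CC[C@@]1(C)O`: 33500 nM
- compound 2 `CC1=CC[C@H]2[C@H](CC[C@]2(C)O)C(C)(C)[C@@H]1CC[C@H]1[C@]2(C)CC[C@H](OC(=O)c3cccc(C(F)(F)F)c3)C(C)(C)O[C@H]2CC[C@@]1(C)O`: 37900 nM
- compound 3 `CC1=CC[C@H]2[C@H](CC[C@]2(C)O)C(C)(C)[C@@H]1CC[C@H]1[C@]2(C)CC[C@H](OC(=O)c3ccccc3Cl)C(C)(C)O[C@H]2CC[C@@]1(C)O`: 12100 nM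

Among these three, compound 3 gives the lowest number, and its steps to both of the others lie beyond the scatter. That makes it the strongest inhibitor of the set, though the numbers for all three remain close together.

Compound 4 `CC1=CC[C@H]2[C@H](CC[C@]2(C)O)C(C)(C)[C@@H]1CC[C@H]1[C@]2(C)CC[C@H](OC(=O)c3ccccc3[N+](=O)[O-])C(C)(C)O[C@H]2CC[C@@]1(C)O` differs from compound 3 in one place: nitro in place of chloro on an aromatic carbon. This is nitro in place of chloro on an aromatic carbon, ortho to a large group.

Going by the values given here, no measured step introduces nitro, so the closest guides are the exchanges of the phenyl group on the carbonyl carbon. These gave a 1.1-fold higher number from compound 1 to compound 2 (0.05 log units; within the scatter), a 2.8-fold lower number from compound 1 to compound 3 (0.44 log units; beyond the scatter) and a 3.1-fold lower number from compound 2 to compound 3 (0.50 log units; beyond the scatter). Even the largest of these is only modest, so a large step is not expected in this assay. Compound 3 sits at the low end with 12100 nM, which gives a weak lean towards a higher number for its neighbour. No step beyond the scatter is expected, and the estimated change is a 1.5-fold higher number from compound 3 to compound 4 (0.17 log units; within the scatter). The expected value for compound 4 is 18000 nM, with an estimated range from 8000 nM to 40000 nM.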

Compound 4, half-maximal inhibitory concentration: 5200 nM
Compound 4: the middle estimate sits 3.5-fold (0.54 log units) above what was measured; the whole stated range lies above it.
By their numbers in this assay, from the lowest: compound 4; then compound 3; then compounds 1 and 2 (each within the scatter of the next).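

At the aromatic carbon ortho to a large group, the choice of group still matters: in this assay, nitro in place of chloro gives a 2.3-fold lower number from compound 3 to compound 4 (0.37 log units; beyond the scatter), so 2-chlorophenyl, the best of the earlier groups, does not mark the limit at this place. Going by these compounds alone, the 2-nitrophenyl group also widens the spread across the series, with a 7.3-fold lower number from compound 2 to compound 4 (0.86 log units; beyond the scatter) and a 6.4-fold lower number from compound 1 to compound 4 (0.81 log units; beyond the scatter), both larger than any step among the earlier compounds though still modest, and compound 4 is now the strongest of the four. Nothing measured here explains why nitro gives the lower number.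

From the compounds shown here alone, it remains open whether nitro would give a similar result on another carbon of the aromatic ring, and whether an amine or a carboxylic acid on this same carbon would move the number lower or higher. Going by these compounds, what happens when the ester link itself changes, for example to an amide, also remains unknown, as all four compounds keep that link and the shared core.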